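The source may report more compounds than this note shows. Statements on the series, on what has been measured and on what is new or still open speak of the compounds shown alone.

In a functional assay on KB cells (Homo sapiens) for antiproliferative activity, read by MTT assay, with a stated time of 48 h (on this read-out higher numbers stand for weaker inhibition and lower numbers for stronger inhibition), compound 2 `Cn1cc(C2=C(c3n[nH]c4ncccc34)C(=O)NC2=O)c2ccccc21` gives 62000 nM, and compound 1 `Cn1cc(C2=C(c3nn(CCCN4CCCCC4)c4ncccc34)C(=O)N(c3cccc4ccccc34)C2=O)c2ccccc21` gives the lower value of 13400 nM, which leaves compound 2 with the higher of the two actual numbers. Compound 3 `Cn1cc(C2=C(c3nn(CCn4ccnc4)c4ncccc34)C(=O)NC2=O)c2ccccc21` gives only a limit, > 100000 nM.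

Compound 4 `Cn1cc(C2=C(c3n[nH]c4ncccc34)C(=O)N(c3cccc4ccccc34)C2=O)c2ccccc21` has not yet been measured. It carries naphthalen-1-yl in place of hydrogen on an amide-type nitrogen in a ring of compound 2: naphthalen-1-yl in place of hydrogen on an amide-type nitrogen in a ring.

Within the data shown here, the one measured step, an at least 1.6-fold higher number from compound 2 to compound 3 (0.20 log units; that floor lies within the scatter), changes an aromatic nitrogen rather than this amide-type nitrogen, and it ends at the limit of > 100000 nM in this assay, at which 1 of the 3 values shown sits, so it says little about the new change. Compound 1 is the closer guide, as it bears naphthalen-1-yl on the same nitrogen and gives 13400 nM. However, compound 1 also carries a chain on an aromatic nitrogen, so the data do not separate the two changes. A lower number than that of compound 2 is therefore expected, but probably not one below that of compound 1 by much. The expected change is a 2.5-fold lower number from compound 2 to compound 4 (0.39 log units; beyond the scatter). For compound 4 the estimate is 25000 nM, with an expected range from 7000 nM to 90000 nM.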

Compound 4, half-maximal inhibitory concentration: > 100000 nM
Compound 4 ended at the assay's limit; the forecaster's own chance of this, stated with the estimate: 15%; middle value at least 4.0-fold (0.60 log units) from the limit.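

Placing naphthalen-1-yl on the amide-type nitrogen does not by itself lower the number in this assay, the step being an at least 1.6-fold higher number from compound 2 to compound 4 (0.20 log units; that floor lies within the scatter). Taking 3-(piperidin-1-yl)propyl off the aromatic nitrogen while naphthalen-1-yl stays gives an at least 7.4-fold higher number from compound 1 to compound 4 (0.87 log units; beyond the scatter), so the stronger inhibition seen earlier goes with that chain together with naphthalen-1-yl and not with naphthalen-1-yl alone, a separation the earlier compounds did not allow. The true size of both steps remains unknown because compound 4 reads as a limit of the assay and not as a number: the limit of > 100000 nM in this assay, at which 2 of the 4 values shown sit.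

Whether 3-(piperidin-1-yl)propyl on the aromatic nitrogen would lower the number without naphthalen-1-yl stays open, and the only other chain shown at that nitrogen, 2-(1H-imidazol-1-yl)ethyl, belongs to compound 3, which also ends at a limit. Also open, on these data alone, is how an amine chain such as 2-(dimethylamino)ethyl on the aromatic nitrogen, or a smaller group such as methyl or phenyl on the amide-type nitrogen, would read in this assay.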